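This account rests on a few compounds, and the source may have more. Where it says the series, first, only, none or still open, it means among the compounds named here.

Within the data shown here, compound 3 `Cn1nccc1-c1cc(C(F)(F)F)ccc1[C@H]1CCOc2cc(S(=O)(=O)Nc3cccc(F)n3)ccc21` stands highest of the three numbers so far in a physicochemical assay for lipophilicity (on this read-out lower numbers stand for lower lipophilicity and higher numbers for higher lipophilicity), giving 3.6; the nearest is compound 1 `Cn1nccc1-c1cc(C(F)(F)F)ccc1[C@H]1CCOc2cc(S(=O)(=O)Nc3ccncn3)ccc21`, which gives 1.8, and furthest is compound 2 `O=S(=O)(Nc1nccs1)c1ccc2c(c1)OCC[C@@H]2c1ccc(C(F)(F)F)cc1N1CCNCC1`, which gives 1.4. Among the measured compounds shown here, the single one-place step measured is a number 1.80 log units higher from compound 1 to compound 3 (beyond the scatter). Compound 4 `Cn1nccc1-c1cc(C(F)(F)F)ccc1[C@H]1CCOc2cc(S(=O)(=O)Nc3nccs3)ccc21` is the next step from compound 3: 1,3-thiazol-2-yl in place of 6-fluoropyridin-2-yl on a sulfonamide nitrogen. For the measured compounds named here, no measured step covers this exact exchange, but compound 2 also carries a 1,3-thiazol-2-yl group on a sulfonamide nitrogen and gives 1.4, though it differs elsewhere, so the change is expected to take the read-out back down well beyond the scatter. The expected step is a number 1.60 log units lower from compound 3 to compound 4 (beyond the scatter). Compound 4 is therefore estimated at 2, within a range of 1.3 to 2.8.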

Compound 4, distribution coefficient: 2.2
Estimate against measurement, compound 4: 0.20 log units below, and the stated range covers the measured number.
By their numbers in this assay, from the lowest: compound 2; then compound 1; then compound 4; then compound 3.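

On the sulfonamide nitrogen, this assay now compares three groups on one core: 1,3-thiazol-2-yl gives a number 1.40 log units lower from compound 3 to compound 4 (beyond the scatter) and a number 0.40 log units higher from compound 1 to compound 4 (beyond the scatter), so it sits far closer to pyrimidin-4-yl than to 6-fluoropyridin-2-yl. With 1,3-thiazol-2-yl held fixed, 1-methyl-1H-pyrazol-5-yl in place of piperazin-1-yl on an aromatic carbon gives a number 0.80 log units higher from compound 2 to compound 4 (beyond the scatter). No evidence on the origin of these steps is available. A plain pyridin-2-yl group on the sulfonamide nitrogen would separate the fluorine from the ring in the large step. From the compounds shown here alone, whether the order of the three groups holds with piperazin-1-yl on the core remains open.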